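Oxime versus ketone on the sulfur-linked chain in rat paw edema

A few compounds are considered here, and "the series" means these few. Any claim that something is new, unique, unknown or untested is made for them only; others in the source may bear on it.

Measured compounds:
compound 1, `COc1ccc(-c2nnc(SCC(=O)c3ccccc3)n2-c2ccccc2)cc1OC`, 59%
compound 2, `C=CCn1c(SC/C(=N/O)c2ccccc2)nnc1-c1ccc(OC)cc1`, 67%
compound 3, `COc1ccc(-c2nnc(SC/C(=N/O)c3ccccc3)n2-c2ccccc2)cc1OC`, 67%

All three were tested in a functional assay on the whole organism (strain albino) for inhibition, with Rattus norvegicus as the target, read by paw edema, with a stated time of 3 h, at a dose of 0.28 mmol/kg by the oral route; a lower number here means less inhibition, a higher number more inhibition at the dose given (going by the name of the read-out). Compound 2 and compound 3 stand level at the digits reported, and compound 1 sits a little lower, though that gap is within the scatter of this kind of measurement. Compound 3 and compound 1 differ in one place: a group of 8 heavy atoms (7 carbon, 1 oxygen; one six-membered aromatic ring of carbon only) in place of a group of 9 heavy atoms (7 carbon, 1 nitrogen, 1 oxygen; one six-membered aromatic ring of carbon only), on a saturated chain carbon bound to a sulfur. That change gave a number 8 percentage points lower from compound 3 to compound 1 (within the scatter), a shift too small to count as a real difference.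

Compound 4, `C=CCn1c(SCC(=O)c2ccccc2)nnc1-c1ccc(OC)cc1`, has not yet been measured. It relates to compound 2 exactly as compound 1 relates to compound 3: a group of 8 heavy atoms (7 carbon, 1 oxygen; one six-membered aromatic ring of carbon only) in place of a group of 9 heavy atoms (7 carbon, 1 nitrogen, 1 oxygen; one six-membered aromatic ring of carbon only), on a saturated chain carbon bound to a sulfur, the same change at the same place. The cores of compound 2 and compound 3 differ as well, but that difference is not broken down here. Resting only on the step seen from compound 3 to compound 1, the expected step from compound 2 to compound 4 in this assay is a number 8 percentage points lower from compound 2 to compound 4 (within the scatter). Compound 4 is therefore estimated at 59%, with a likely range from 44% to 72%.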

Compound 4, a percentage reported as inhibition, in the whole organism at one dose (the size of the read-out at that dose, not a potency): 63%
The estimate for compound 4 lay 4 percentage points below the measured number; the measured number falls inside the stated range.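

In this assay, putting benzoyl in place of the oxime-bearing group on the core of compound 2 gave a number 4 percentage points lower from compound 2 to compound 4 (within the scatter). Set beside the step already seen on the core of compound 3, the new step tells the same story: the same change on two cores in this assay, a number 8 percentage points lower (within the scatter) from compound 3 to compound 1 and a number 4 percentage points lower (within the scatter) from compound 2 to compound 4, 4 percentage points apart, within the scatter of two such steps So on these two cores the swap carries over in the sense that neither step stands out from the noise of the measurement, but this does not show that the ketone truly lowers the effect, nor that the same would hold on any third core, and a single dose gives a size of effect rather than a potency.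

The compounds shown leave open how this read-out would respond to something quite different on the saturated chain carbon bound to a sulfur, such as an amine, a carboxylic acid or a longer chain in place of benzoyl. They also leave open whether any such group would move the number by more than the usual scatter.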